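The compounds below may be only part of what the source reports. "The series", "measured", "known", "first", "only" and "open" are said of these compounds alone.

Measured in a physicochemical assay for lipophilicity, at pH 7.4; on this read-out higher numbers stand for higher lipophilicity and lower numbers for lower lipophilicity:
- compound 1 `CCc1ccc(N(CC(C)C)S(=O)(=O)c2ccc3c(c2)C(O)CC(C2CCOCC2)O3)cc1`: 4.12
- compound 2 `CCc1ccc(N(CC(C)C)S(=O)(=O)c2ccc3c(c2)C(C)CC(C2CCOCC2)O3)cc1`: 5.71
- compound 3 `CCc1ccc(N(CC(C)C)S(=O)(=O)c2ccc3c(c2)C(OC)CC(C2CCOCC2)O3)cc1`: 4.69

Compound 2 stands highest of the three, with compound 3 the nearest to it. Compound 4 `CCc1ccc(N(CC(C)C)S(=O)(=O)c2ccc3c(c2)C(C)(O)CC(C2CCOCC2)O3)cc1` differs from compound 2 by one change: hydroxy in place of hydrogen on a saturated ring carbon. For the measured compounds named here, no measured step makes exactly this change. The closest is a number 1.59 log units higher from compound 1 to compound 2 (beyond the scatter), a large step for methyl in place of hydroxy, which read in reverse points downward. a number 1.02 log units lower from compound 2 to compound 3 (beyond the scatter), also large, points the same way, while a number 0.57 log units higher from compound 1 to compound 3 (beyond the scatter) is modest. Compound 4 keeps a methyl that compound 1 lacks, so a slightly smaller fall is expected, a large one nonetheless: a number 1.31 log units lower from compound 2 to compound 4 (beyond the scatter). For compound 4 the estimated value is 4.4, with an expected range from 4 to 4.9.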

Compound 4, distribution coefficient: 4.19
Beside the measured number, compound 4's estimate is 0.21 log units above it; the measured number falls inside the stated range.
By their numbers in this assay, from the lowest: compounds 1 and 4 (each within the scatter of the next); then compound 3; then compound 2.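

In this assay hydroxy in place of hydrogen on this saturated ring carbon gives a number 1.52 log units lower from compound 2 to compound 4 (beyond the scatter) and so shows a large step with the methyl kept on that carbon, a case that compound 1, compound 2 and compound 3 did not cover. With the hydroxy kept, methyl in place of hydrogen on the same carbon gives a number 0.07 log units higher from compound 1 to compound 4 (within the scatter) and so separates compound 1 and compound 4 by no more than the scatter.

On these data alone, whether an amine or a longer chain such as ethyl on this carbon would behave like the hydroxy or the methyl stays open. Nothing at hand gives a reason for either step.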